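A side chain exchange on the shared core

The source may report more compounds than this note shows. Statements on the series, on what has been measured and on what is new or still open speak of the compounds shown alone.

Compound 1 `Cc1cc(/C=C/C#N)cc(C)c1Oc1cc(Cl)nc(Nc2ccc(C#N)cc2)n1`: 4310 nM
Compound 2 `Cc1cc(/C=C/C#N)cc(C)c1Oc1cc(NCCN2CCNCC2)nc(Nc2ccc(C#N)cc2)n1`: 3650 nM

Among the compounds with values here, in an ADME assay on MT4 cells (Homo sapiens) for cytotoxicity, read by MTT assay, with a stated time of 5 days (a lower number here means that less compound is tolerated, a higher number that more compound is tolerated), compound 2 stands level with compound 1, the only other compound measured. Compound 3 `Cc1cc(/C=C/C#N)cc(C)c1Oc1cc(NCC2CCCO2)nc(Nc2ccc(C#N)cc2)n1` differs from compound 2 by one change: oxolan-2-yl in place of (piperazin-1-yl)methyl on a saturated chain carbon bound to a nitrogen on an aromatic ring. Within the data shown here, the only measured step that bears on it, a 1.2-fold lower number from compound 1 to compound 2 (0.07 log units; within the scatter), stayed within the scatter, although it exchanged chloro for the whole side chain. No step beyond the scatter is therefore expected in this assay. The expected step is a 1.3-fold higher number from compound 2 to compound 3 (0.12 log units; within the scatter). Compound 3 is estimated at 4800 nM, with an expected range from 2200 nM to 12000 nM.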

Compound 3, half-maximal cytotoxic concentration: > 268000 nM
Compound 3: no number, only a limit (the forecaster's own chance of this, stated with the estimate: 15%); at least 55-fold (1.74 log units) between middle value and limit.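

In this assay, this place on a saturated chain carbon bound to a nitrogen on an aromatic ring proved able to shift the number strongly: oxolan-2-yl in place of (piperazin-1-yl)methyl gave an at least 73-fold higher number from compound 2 to compound 3 (1.86 log units; beyond the scatter). The exchange of chloro for ((oxolan-2-yl)methyl)amino gave an at least 62-fold higher number from compound 1 to compound 3 (1.79 log units; beyond the scatter), whereas the exchange for the piperazine side chain had stayed within the scatter, so the outcome depends on which side chain enters. For compound 3 the reading is a limit, not a number: the limit of > 268000 nM in this assay, at which 1 of the 3 values shown sits.

On these data alone, it remains open whether a morpholin-4-yl group or an open methoxyethyl chain in the same place would read like compound 2 or like compound 3, and so which part of the exchange carries the step.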